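The compounds below may be only part of what the source reports. "The series", "measured", "known", "first", "only" and "open" are said of these compounds alone.

Compound 1 `CCC[C@@H](N)C(=O)NCc1ccccc1`: 21 mg/kg
Compound 2 `NCC(N)C(=O)NCc1ccccc1`: limit, > 68 mg/kg

For the measured compounds named here, compound 1 `CCC[C@@H](N)C(=O)NCc1ccccc1` is the only compound with a number in a functional assay on the whole organism (strain NMRI) with Mus musculus as the target, in the maximal electroshock model, with a stated time of 30 min; on this read-out lower numbers stand for an effect already at smaller amounts and higher numbers for an effect only at larger amounts of compound; compound 1 gives 21 mg/kg there. Compound 2 `NCC(N)C(=O)NCc1ccccc1` reaches only a limit in this assay, > 68 mg/kg, and so no number is known for it. Going by the values given here, the single measured step, an at least 3.2-fold higher number from compound 1 to compound 2 (0.51 log units; beyond the scatter), concerns the replacement the limit of > 68 mg/kg in this assay, at which 1 of the 2 values shown sits, and is not of the same kind as the change now followed.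

Compound 3 `CCCC[C@@H](N)C(=O)NCc1ccccc1` differs from compound 1 by methyl in place of hydrogen on a saturated chain carbon, four bonds along the chain from an amine nitrogen and a carbonyl carbon. Among the compounds with values here, no measured step tracks such a lengthening of the saturated chain, so the expectation rests on the closeness of the two structures alone. The step is expected to be a 1.1-fold lower number from compound 1 to compound 3 (0.02 log units; within the scatter), within the scatter. Compound 3 is therefore estimated at 20 mg/kg in this assay, between 8 mg/kg and 50 mg/kg.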

Compound 3, dose for half-maximal effect: 23 mg/kg
Compound 3: middle estimate off by 1.2-fold (0.06 log units), on the low side, within the range that was stated.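

In this assay, methyl in place of hydrogen on a saturated chain carbon, four bonds along the chain from an amine nitrogen and a carbonyl carbon, gives a 1.1-fold higher number from compound 1 to compound 3 (0.04 log units; within the scatter), so at this position the two compounds cannot be told apart on this read-out. For the compounds shown here, this pair is the first in which both partners carry a number, and it shows that propyl to butyl on the shared core is tolerated in this assay, at least for this one added carbon. Compound 2 remains a limit and not a number, the only such value in the set: the limit of > 68 mg/kg in this assay, at which 1 of the 3 values shown sits.

On these data alone, whether a still longer chain such as pentyl or hexyl would stay within the scatter of compound 1 remains open. So does the outcome with a branched chain such as isobutyl, or with a phenyl ring, at the same place.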